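The source may report more compounds than this note shows. Statements on the series, on what has been measured and on what is new or still open speak of the compounds shown alone.

Measured so far:
- Compound 1 `O=C1Nc2ccc(F)cc2/C1=C\C(=O)c1ccc(C2CCCCC2)cc1`: 2730 nM
- Compound 2 `CN1CCN(c2cccc(N/C=C3\C(=O)Nc4ccc(NC(=O)c5cccc(F)c5)cc43)c2)CC1`: 4280 nM

Both compounds were tested in a functional assay on NCI-H1650 cells (Homo sapiens) for inhibition, read by sulforhodamine B assay, with a stated time of 3 days; a higher number here means a weaker inhibitor, a lower number a stronger inhibitor. Among the compounds with values here, compound 2 gives the higher of only two numbers, 4280 nM, but the gap to compound 1 at 2730 nM lies within the usual scatter of repeated measurements. The two therefore cannot be ranked, and their structures differ in more than one place, so the pair reveals no effect of any single change.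

The next compound, compound 3 `CN1CCN(c2cccc(N/C=C3\C(=O)Nc4ccc(NC(=O)c5c(Cl)cccc5Cl)cc43)c2)CC1`, keeps compound 2 intact except at one place. It has 2,6-dichlorophenyl in place of 3-fluorophenyl on a carbonyl carbon whose other neighbours are: amide-type nitrogen (2,6-dichlorophenyl in place of 3-fluorophenyl on a carbonyl carbon).

Within the data shown here, no measured pair shows what this swap does in this assay, so the best anchor is compound 2 itself at 4280 nM. With no evidence for a direction, the expected change a 1.1-fold lower number from compound 2 to compound 3 (0.03 log units; within the scatter) stays within the scatter. For compound 3 the estimated value is 4000 nM, with an expected range from 1300 nM to 12000 nM.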

Compound 3, half-maximal inhibitory concentration: 2170 nM
The estimate for compound 3 lay 1.8-fold (0.27 log units) above the measured number; the measured number falls inside the stated range.
By their numbers in this assay, from the lowest: compounds 3, 1 and 2 (each within the scatter of the next).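

In this assay, placing 2,6-dichlorophenyl in place of 3-fluorophenyl on a carbonyl carbon gives a 2.0-fold lower number from compound 2 to compound 3 (0.29 log units; within the scatter), so the two compounds cannot be told apart in this cell assay. Within the data shown here, this is the first direct reading at this position: with the rest of the molecule held fixed, a ring carrying two chlorine atoms and a ring carrying one fluorine atom give numbers that cannot be separated, so this one change has no effect that can be distinguished from ordinary repeat-to-repeat variation. No independent measurement accompanies these numbers to explain why they lie so close together.

This single pair cannot show whether the position would respond to a more different group, such as an amine or a carboxylic acid on the ring, or a longer carbon chain in place of the ring. It also leaves open whether the same swap would give a similarly small step on the different framework of compound 1, or in compounds changed elsewhere.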